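Vero cell cytotoxicity notes toward compound 4

A few compounds are considered here, and "the series" means these few. Any claim that something is new, unique, unknown or untested is made for them only; others in the source may bear on it.

Measured so far:
compound 1 `O=c1nc(N2CCN(NCC3CCCCC3)CC2)sc2c([N+](=O)[O-])cc(C(F)(F)F)cc12`: 29.3 ug/mL
compound 2 `O=c1nc(N2CCN(NCc3ccc(OC(F)(F)F)cc3)CC2)sc2c([N+](=O)[O-])cc(C(F)(F)F)cc12`: > 64 ug/mL (a limit)
compound 3 `COc1ccc(CNN2CCN(c3nc(=O)c4cc(C(F)(F)F)cc([N+](=O)[O-])c4s3)CC2)cc1`: > 64 ug/mL (a limit)

In an ADME assay on Vero cells (Chlorocebus sabaeus) for cytotoxicity, read by MTT assay, with a stated time of 72 h (on this read-out higher numbers stand for lower toxicity in this test and lower numbers for higher toxicity in this test), compound 1 gives 29.3 ug/mL. Compound 2 reaches only the limit of the assay, > 64 ug/mL. Compound 3 likewise stands only at the limit, > 64 ug/mL. Compound 3 thus has no number of its own; one further value shown is also a limit (the limit of > 64 ug/mL in this assay, at which 2 of the 3 values shown sit).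

Compound 4 `O=c1nc(N2CCN(Nc3ccc(C(F)(F)F)cc3)CC2)sc2c([N+](=O)[O-])cc(C(F)(F)F)cc12` differs from compound 3 by 4-(trifluoromethyl)phenyl in place of 4-methoxybenzyl on an amine nitrogen. The steps of an at least 2.1-fold higher number from compound 1 to compound 2 (0.33 log units; beyond the scatter) and an at least 2.1-fold higher number from compound 1 to compound 3 (0.33 log units; beyond the scatter) show that an aromatic ring in place of cyclohexyl on that chain carbon moves the number past the limit; the step that the two limits leave unreadable from compound 2 to compound 3 cannot be read. Within the data shown here, no measured step covers an aromatic ring placed directly on the amine nitrogen. The expectation is a step of an at least 1.2-fold lower number from compound 3 to compound 4 (0.10 log units; that floor lies within the scatter). Compound 4 is estimated at 50 ug/mL (20 ug/mL to 64 ug/mL), with a fair chance that again only the limit is reported.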

Compound 4, half-maximal cytotoxic concentration: > 64 ug/mL
Compound 4: only a limit was reported; the forecaster's own chance of this, stated with the estimate: 50%; middle value at least 1.2-fold (0.10 log units) from the limit.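

In this assay, the gain over the cyclohexylmethyl group no longer depends on a saturated chain carbon: 4-(trifluoromethyl)phenyl directly on the amine nitrogen gives an at least 2.1-fold higher number from compound 1 to compound 4 (0.33 log units; beyond the scatter). Among the compounds shown, only compound 1 has a number of its own, and its group is the only one without an aromatic ring. The steps among compound 2, compound 3 and compound 4 cannot be read: the limit of > 64 ug/mL in this assay, at which 3 of the 4 values shown sit.

Any order among these three aromatic groups stays open. Also open, on these data alone, is how a carboxylic acid or an amine in place of trifluoromethyl on the phenyl ring would read.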